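Moving the methoxy group on the biaryl of compound 3

The compounds below may be only part of what the source reports. "The series", "measured", "known", "first", "only" and "open" are said of these compounds alone.

Compound 3 `COc1ccc(-c2ccc(N(C[C@@H](N)CC(C)C)C(=O)[C@@H]3C[C@H]3c3ccccc3)cc2)cc1` gives the lowest number of the three measured in a functional assay for agonist activity at G protein-coupled receptor 88 (Homo sapiens), read by HTRF and cAMP accumulation (a higher number here means that more compound is needed for the effect, a lower number that less compound is needed), namely 330 nM. Compound 1 `CC(C)C[C@H](N)CN(C(=O)[C@@H]1C[C@H]1c1ccccc1)c1ccc(-c2ccccc2)cc1` gives 880 nM, and compound 2 `CC(C)C[C@H](N)CN(C(=O)[C@@H]1C[C@H]1c1ccccc1)c1ccc(-c2cccnc2)cc1` gives 10000 nM. The measured steps are a 2.7-fold lower number from compound 1 to compound 3 (0.43 log units; beyond the scatter), an 11-fold higher number from compound 1 to compound 2 (1.06 log units; beyond the scatter) and a 30-fold lower number from compound 2 to compound 3 (1.48 log units; beyond the scatter). Compound 4 `COc1ccccc1-c1ccc(N(C[C@@H](N)CC(C)C)C(=O)[C@@H]2C[C@H]2c2ccccc2)cc1` is not yet measured; the change is 2-methoxyphenyl in place of 4-methoxyphenyl on an aromatic carbon. Going by the values given here, no measured step relocates a substituent on the outer ring, so the bearing is indirect: a 2.7-fold lower number from compound 1 to compound 3 (0.43 log units; beyond the scatter) shows a modest gain when the methoxy enters, while an 11-fold higher number from compound 1 to compound 2 (1.06 log units; beyond the scatter) shows a large loss on altering the outer ring. The expected step is a 2.1-fold higher number from compound 3 to compound 4 (0.33 log units; beyond the scatter), in the direction of a higher number. Compound 4 is estimated at 700 nM, within 250 nM to 2500 nM.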

Compound 4, half-maximal effective concentration: 3200 nM
Compound 4: middle estimate off by 4.6-fold (0.66 log units), on the low side; measured number above the stated range.
By their numbers in this assay, from the lowest: compound 3; then compound 1; then compound 4; then compound 2.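

In this assay moving the methoxy on the outer ring turns a gain into a loss, with a 9.7-fold higher number from compound 3 to compound 4 (0.99 log units; beyond the scatter) on going to 2-methoxyphenyl and a 3.6-fold higher number from compound 1 to compound 4 (0.56 log units; beyond the scatter) against the unsubstituted phenyl, so the result of adding this group depends on where it sits. The 2-methoxyphenyl still compares well with pyridin-3-yl, with a 3.1-fold lower number from compound 2 to compound 4 (0.49 log units; beyond the scatter) in favour of the methoxy compound. No evidence to hand bears on why the placement counts for so much.

Still open, on these data alone, is whether another group in the same place, such as fluorine or a hydroxyl, shows the same order between the two placements. Also open, as far as these compounds go, is how an amine on the outer ring would compare with the 4-methoxyphenyl.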